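The compounds below may be only part of what the source reports. "The series", "measured", "known", "first", "only" and "open" are said of these compounds alone.

Measured so far:
- compound 1, `COc1ncc(-c2ccccc2)cc1[C@@H](c1ccccc1)[C@@](O)(CCN(C)C)c1cc(F)cc(F)c1`: > 50 ug/mL in a toxicity assay on Vero cells (Chlorocebus sabaeus) for cytotoxicity; a higher number here means that more compound is tolerated, a lower number that less compound is tolerated
- compound 2, `COc1ccc(-c2ccc([C@@H](c3ccccc3)[C@@](O)(CCN(C)C)c3cccc4ccccc34)c(OC)n2)cc1`: > 50 ug/mL in this assay

The value of compound 1 in this assay is a limit of the assay, not a number. The value of compound 2 in this assay is likewise a limit. Among the measured compounds shown here, both values sit at the limit of > 50 ug/mL in this assay, at which 2 of the 2 values shown sit, so no ordering between compound 1 and compound 2 can be read from this assay, and no step between measured compounds is available.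

Compound 3, `COc1nc(-c2cnsc2)ccc1[C@@H](c1ccccc1)[C@@](O)(CCN(C)C)c1cccc2ccccc12`, has not yet been measured in this assay. It differs from compound 2 as follows: 1,2-thiazol-4-yl in place of 4-methoxyphenyl on an aromatic carbon.

With both measured values at the limit, no change beyond the scatter is expected in this assay for this change. Compound 3 is expected to tolerate about 50 ug/mL, with a range from 25 ug/mL to 100 ug/mL, most likely again reported as a limit. The expected step is a number no higher from compound 2 to compound 3 (the limit leaves the size open).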

Compound 3, half-maximal cytotoxic concentration: 26.3 ug/mL
Beside the measured number, compound 3's estimate is 1.9-fold (0.28 log units) above it; the measured number falls inside the stated range.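

In this assay, among the compounds shown here, compound 3 gives 26.3 ug/mL, the only value shown so far that is a number rather than a limit of the assay. Compound 2 sits at > 50 ug/mL, which is a limit of the assay. The exchange of 4-methoxyphenyl for 1,2-thiazol-4-yl, on the aromatic carbon next to the ring nitrogen, can therefore be read only as a floor, an at least 1.9-fold lower number from compound 2 to compound 3 (0.27 log units; that floor lies within the scatter), so this position can bring the value in this assay within the measurable range, but a real loss of tolerance is not established.

As far as these compounds go, the true size of the step stays open: the limit of > 50 ug/mL in this assay, at which 2 of the 3 values shown sit. Also open is how this assay responds at this position to a non-aromatic group, such as an amine or a carboxylic acid, in place of the aromatic ring.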